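Phenyl in place of propyl on the carbamate chain

This account rests on a few compounds, and the source may have more. Where it says the series, first, only, none or still open, it means among the compounds named here.

In an assay on nucleic acid for inhibition of Nucleic Acid, read by fluorescence, tested at 100 uM (a higher number here means more inhibition at the concentration tested (going by the name of the read-out), a lower number less inhibition), compound 2 `CCCCNC(=O)OCC(O)Cn1cc(CN(C)CCC(C)C)nn1` gives 24%, the lowest of the two numbers measured, while compound 1 `CCCCN(CCCC)Cc1cn(CC(O)COC(=O)NCc2ccccc2)nn1` gives 42%, beyond the scatter above it. Among the measured compounds shown here, no single-point step between measured compounds is available, so the expected size of the step into compound 3 `CC(C)CCN(C)Cc1cn(CC(O)COC(=O)NCc2ccccc2)nn1` rests on that comparison alone. The change from compound 2 to compound 3 is phenyl in place of propyl on a saturated chain carbon bound to an amide-type nitrogen. In this assay a rise beyond the scatter is expected, since compound 1 also carries a benzyl carbamate and gives 42%. Compound 3 is estimated at 36%, with a range from 18% to 54%, a step of a number 12 percentage points higher from compound 2 to compound 3 (beyond the scatter).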

Compound 3, a percentage reported as inhibition, at one concentration (the size of the read-out at that concentration, not a potency): 26%
Compound 3: the middle estimate sits 10 percentage points above what was measured; the range from low to high includes it.
By their numbers in this assay, from the lowest: compounds 2 and 3 (each within the scatter of the next); then compound 1.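

In this assay, phenyl in place of propyl on a saturated chain carbon bound to an amide-type nitrogen gives a number 2 percentage points higher from compound 2 to compound 3 (within the scatter), so this change alone does not shift the read-out. With the benzyl carbamate held constant, isopentyl(methyl)amino in place of dibutylamino gives a number 16 percentage points lower from compound 1 to compound 3 (beyond the scatter), so the higher number of compound 1 goes with its dibutylamino group, not its benzyl carbamate. No measurement here explains either step. The compounds shown leave open whether dibutylamino gives a similar number alongside the butyl carbamate, and what pyridyl in place of phenyl would give.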